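This account rests on a few compounds, and the source may have more. Where it says the series, first, only, none or still open, it means among the compounds named here.

Values so far in a functional assay on A549 cells (Homo sapiens) for antiproliferative activity, read by MTT assay, with a stated time of 48 h; on this read-out lower numbers stand for stronger inhibition and higher numbers for weaker inhibition

Compound 1 `O=C(/C=C/c1ccc(O)c(O)c1)N1CCN(c2ccc(F)cc2)CC1` gives 1.25 ug/mL
Compound 2 `O=C(/C=C/c1ccc(O)c(O)c1)N1CCN(c2ccccc2Cl)CC1` gives 1.44 ug/mL
Compound 3 `COc1ccc(N2CCN(C(=O)/C=C/c3ccc(O)c(O)c3)CC2)cc1` gives 0.93 ug/mL

On these numbers compound 3 cannot be separated from the other two, as the steps to it (a 1.3-fold lower number from compound 1 to compound 3 (0.13 log units; within the scatter)) and (a 1.5-fold lower number from compound 2 to compound 3 (0.19 log units; within the scatter)) both stay within the scatter. Compound 4 `O=C(/C=C/c1ccc(O)c(O)c1)N1CCN(c2ccc([N+](=O)[O-])cc2)CC1` has not yet been measured. It differs from compound 3 by one group (nitro in place of methoxy on an aromatic carbon), with nitro in place of methoxy on an aromatic carbon, para to a large group. Going by the values given here, no measured compound carries a nitro, so the evidence is indirect. The three changes of substituent seen so far include (a 1.2-fold higher number from compound 1 to compound 2 (0.06 log units; within the scatter)), and none of them leaves the scatter. In this assay the expectation is therefore no step beyond the scatter and no firm direction. The estimated step is small (a 1.3-fold higher number from compound 3 to compound 4 (0.11 log units; within the scatter)). For compound 4 the expected value is 1.2 ug/mL with an estimated range from 0.6 ug/mL to 2.4 ug/mL (the upper and lower ends of that expectation).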

Compound 4, half-maximal inhibitory concentration: 1.56 ug/mL
Estimate against measurement, compound 4: 1.3-fold (0.11 log units) below; low and high end bracket the measured number.
By their numbers in this assay, from the lowest: compounds 3, 1, 2 and 4 (each within the scatter of the next).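

In this assay, nitro on this aromatic carbon, para to a large group, joins methoxy and fluoro without leaving the scatter (a 1.7-fold higher number from compound 3 to compound 4 (0.22 log units; within the scatter); a 1.2-fold higher number from compound 1 to compound 4 (0.10 log units; within the scatter)), and the 4-nitrophenyl group cannot be separated from the 2-chlorophenyl group either (a 1.1-fold higher number from compound 2 to compound 4 (0.03 log units; within the scatter)). Even the exchange of methoxy for nitro, which replaces a group of two heavy atoms and one hydrogen-bond acceptor with one of three heavy atoms and two acceptors, therefore gives no readable change at this position among these four compounds. Nothing available explains why the values stay so close.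

The compounds shown leave open whether an amine or a carboxylic acid on this aromatic carbon would step beyond the scatter. They also leave open whether changing the two hydroxy groups on the shared core would do so.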